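Moving Two Chlorines Around a Phenyl on a Triazole

The source may hold more compounds than are shown below. What is called first, only, known or untested is meant among the compounds shown, and "the series" means these compounds.

Compound 1, `N#CC1=C(N)Oc2c(c3nc4ccccc4nc3c3ccccc23)C12C(=O)N(Cc1cnnn1-c1ccc(N)cc1)c1ccccc12`, was tested in a functional assay on HCT-116 cells (Homo sapiens) for antiproliferative activity, read by MTT assay, with a stated time of 48 h (a lower number here means a stronger inhibitor, a higher number a weaker inhibitor), where compound 1 gives 45200 nM. Compound 2, `N#CC1=C(N)Oc2c(c3nc4ccccc4nc3c3ccccc23)C12C(=O)N(Cc1cnnn1-c1cc(Cl)ccc1Cl)c1ccccc12`, carries a 2,5-dichlorophenyl in place of the 4-aminophenyl on the aromatic nitrogen. For compound 2 this assay reports only a limit, > 50000 nM. The step of an at least 1.1-fold higher number from compound 1 to compound 2 (0.04 log units; that floor lies within the scatter) therefore has only a floor, and that floor sits within the usual scatter, so compound 2 stands at the weak end of what was measured, with no number of its own; the limit of > 50000 nM in this assay, at which 1 of the 2 values shown sits, makes the comparison one-sided.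

Compound 3, `N#CC1=C(N)Oc2c(c3nc4ccccc4nc3c3ccccc23)C12C(=O)N(Cc1cnnn1-c1ccc(Cl)c(Cl)c1)c1ccccc12`, differs from compound 2 by 3,4-dichlorophenyl in place of 2,5-dichlorophenyl on an aromatic nitrogen. Among the compounds with values here, no measured step moves chlorine atoms around the same phenyl ring; the one step on record swaps a whole group at that nitrogen and was itself within the scatter. Nothing on record argues for a step beyond the scatter in either direction. The step of a number no higher from compound 2 to compound 3 (the limit leaves the size open) is expected to be essentially none. Compound 3 is estimated to give 50000 nM in this assay, within a range from 25000 nM to 100000 nM, with a real chance that only a limit is reported again.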

Compound 3, half-maximal inhibitory concentration: > 50000 nM
Compound 3 was reported as a limit; the forecaster's own chance of this, stated with the estimate: 55%; the middle value lies on the limit itself.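

In this assay compound 3, like compound 2, is reported only as a limit, so a second placement of the two chlorines on this phenyl ring yields no number of its own: the limit of > 50000 nM in this assay, at which 2 of the 3 values shown sit. The step between these two dichlorophenyl compounds cannot be read, and the data therefore do not tell whether the placement of the chlorines matters at this nitrogen. Against the 4-aminophenyl, the only group here with a measured number, the change to 3,4-dichlorophenyl gives an at least 1.1-fold higher number from compound 1 to compound 3 (0.04 log units; that floor lies within the scatter) and this one-sided floor matches what the 2,5-dichlorophenyl gave, so neither dichlorophenyl is shown to separate from the 4-aminophenyl.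

The compounds shown leave open whether any other group at this nitrogen, such as a phenyl carrying a hydroxyl, a methoxy or a carboxylic acid, or a benzyl in place of the phenyl, would give a clearly lower number in this assay than the 4-aminophenyl does. They also leave open whether a phenyl with a single chlorine would give a readable number, which two chlorines have not done in either placement shown.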